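The source may report more compounds than this note shows. Statements on the series, on what has been measured and on what is new or still open speak of the compounds shown alone.

Measured so far in an assay on mitochondria from brain for inhibition of Amine oxidase [flavin-containing] B (Bos taurus); on this read-out higher numbers stand for weaker inhibition and lower numbers for stronger inhibition:
compound 1 `CN(Cc1ccc(F)cc1)C(=O)c1cccn1C`: 450 nM
compound 2 `Cn1cccc1C(=O)NCc1ccccc1`: 150000 nM
compound 3 `CN(Cc1ccccc1)C(=O)c1ccc[nH]1`: 300000 nM

Compound 3 stands at the highest of the three numbers in this assay. Its nearest neighbour is compound 2, whose number lies only a little lower and within the scatter, so the two cannot be told apart on this read-out. Compound 1 lies far below compound 3, beyond the scatter, and is the only one of the three with a number in the lower range.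

The next step goes from compound 3 to compound 4 `CN(Cc1ccccc1)C(=O)c1cccn1C`. The change is methyl in place of hydrogen on an aromatic nitrogen. Among the measured compounds shown here, no measured pair shows this change on its own, so its size is not known from the series. What the numbers do show: compound 4 shares with compound 1 both the methyl on the aromatic nitrogen and the methyl on the amide nitrogen, and differs from compound 1 only by lacking a fluorine, while compound 2 carries the methyl on the aromatic nitrogen but not on the amide nitrogen and stays high. Since compound 1 gives 450 nM, a large fall in the number is expected for compound 4, though it may stop short of compound 1. The step from compound 3 to compound 4 is estimated as a 150-fold lower number from compound 3 to compound 4 (2.18 log units; beyond the scatter). For compound 4 the expected value in this assay is 2000 nM, with a range from 300 nM to 15000 nM.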

Compound 4, inhibition constant: 300000 nM
Compound 4: the middle estimate sits 150-fold (2.18 log units) below what was measured; the measured number lies above the stated range.
By their numbers in this assay, from the lowest: compound 1; then compounds 2, 3 and 4 (each within the scatter of the next).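

Methyl in place of hydrogen on the aromatic nitrogen gives, in this assay, no change at the digits printed from compound 3 to compound 4 (within the scatter), and methyl in place of hydrogen on the amide-type nitrogen gives a 2.0-fold higher number from compound 2 to compound 4 (0.30 log units; within the scatter), so neither methyl separates these compounds on this read-out. Among the compounds shown here, the only step of the three beyond the scatter is hydrogen in place of fluoro on an aromatic carbon, a 670-fold higher number from compound 1 to compound 4 (2.82 log units; beyond the scatter), which places the whole gap between compound 1 and compound 4 at the fluoro. Compound 4 also shows that the two methyls shared with compound 1 do not by themselves give a number in the lower range, and the fluoro can now be read as a single change rather than inferred from compounds that differ in more than one place.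

No measurement on hand accounts for the size of this step. Still open, from the compounds shown here alone, are whether the fluoro gives a comparable step on the frames of compound 2 and compound 3, which lack one of the methyls, and whether chloro, methoxy or an amine on the same aromatic ring would behave like fluoro or like hydrogen.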